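Nitro in place of methyl: compound 3 to compound 4

The source may hold more compounds than are shown below. What is called first, only, known or untested is meant among the compounds shown, and "the series" means these compounds.

Values in a functional assay on the whole organism (Hindlimb, strain albino) with Mus musculus as the target, in the maximal electroshock model, with a stated time of 0.5 h (a lower number here means that less compound is needed, a higher number that more compound is needed for the effect), so far:
compound 1 `COc1ccc(C2CC(Nc3nc4ccc([N+](=O)[O-])cc4s3)=NN2C(C)=O)cc1` gives 145 umol/kg
compound 2 `COc1ccc(C2CC(Nc3nc4ccc(Cl)cc4s3)=NN2C(C)=O)cc1O` gives 127 umol/kg
compound 3 `COc1ccc(C2CC(Nc3nc4ccc(C)cc4s3)=NN2C(C)=O)cc1O` gives 73.9 umol/kg

Compound 3 at 73.9 umol/kg lies within the scatter of both compound 2 and compound 1, so the three values do not separate from one another.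

The next compound is compound 4 `COc1ccc(C2CC(Nc3nc4ccc([N+](=O)[O-])cc4s3)=NN2C(C)=O)cc1O` and the change from compound 3 is nitro in place of methyl on an aromatic carbon with nitro in place of methyl on an aromatic carbon.

Among the measured compounds shown here, one measured step bears on this carbon directly. It is a 1.7-fold lower number from compound 2 to compound 3 (0.24 log units; within the scatter) and it involves chloro and methyl, not nitro. For the measured compounds named here, a nitro group also occurs in compound 1 at 145 umol/kg but that compound differs from compound 4 elsewhere, so no measured pair isolates the nitro group.

On this evidence, no step beyond the scatter is expected in this assay and any drift is expected to lean slightly toward a higher number. The estimated step is a 1.6-fold higher number from compound 3 to compound 4 (0.19 log units; within the scatter) and it remains tentative with so few compounds. Compound 4 is estimated at 115 umol/kg with 55 umol/kg to 230 umol/kg as the expected range.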

Compound 4, dose for half-maximal effect: 178 umol/kg
For compound 4 the middle estimate is 1.5-fold (0.19 log units) below the measured one; the measured number falls inside the stated range.
By their numbers in this assay, from the lowest: compounds 3, 2, 1 and 4 (each within the scatter of the next, the first and the last beyond it).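

In this assay, among the compounds shown here, nitro in place of methyl on an aromatic carbon gives a 2.4-fold higher number from compound 3 to compound 4 (0.38 log units; beyond the scatter), a modest change and the only step at this carbon that lies beyond the scatter, whereas methyl in place of chloro gives a 1.7-fold lower number from compound 2 to compound 3 (0.24 log units; within the scatter), which does not. Nitro in place of chloro at the same carbon gives a 1.4-fold higher number from compound 2 to compound 4 (0.15 log units; within the scatter), also within the scatter, so among the three groups at this carbon only methyl and nitro separate, and chloro separates from neither. With nitro held in place, hydroxy in place of hydrogen on an aromatic carbon gives a 1.2-fold higher number from compound 1 to compound 4 (0.09 log units; within the scatter), again within the scatter, so this second change has no effect that can be told apart from the noise of the assay.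

On these data alone, how an amine or a carboxylic acid at the nitro-bearing carbon would compare remains open, as does whether the hydroxy step would stay within the scatter with methyl or chloro at that carbon. No measurement on hand accounts for the separation between methyl and nitro.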